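Chloro on the pendant phenyl ring: one change, two cores

The compounds below may be only part of what the source reports. "The series", "measured", "known", "first", "only" and "open" are said of these compounds alone.

Measured so far:
compound 1, `Cn1c(SCC(=O)Nn2c(COc3ccc(Cl)cc3Cl)nc3ccccc3c2=O)nc(-c2ccccc2)c(C#N)c1=O`, 54.6%
compound 2, `Cn1c(SCC(=O)Nn2c(COc3ccc(Cl)cc3Cl)nc3ccccc3c2=O)nc(-c2ccc(Cl)cc2)c(C#N)c1=O`, 76.4%
compound 3, `N#Cc1c(Nc2ccccc2)nc(SCC(=O)Nn2c(COc3ccc(Cl)cc3Cl)nc3ccccc3c2=O)nc1-c1ccc(O)cc1`, 90.9%

In a functional assay on the whole organism (strain albino) for inhibition, with Rattus norvegicus as the target, read by paw edema, with a stated time of 1 h, at a dose of 100 mg/kg by the oral route (on this read-out lower numbers stand for less inhibition and higher numbers for more inhibition at the one dose given (going by the name of the read-out)), compound 1 gives 54.6%. Compound 2 carries the change chloro in place of hydrogen on an aromatic carbon and, in this assay, compound 2 gives 76.4%, so that a number 21.8 percentage points higher from compound 1 to compound 2 (beyond the scatter). Compound 3 rests on a different core; the difference between the two cores is not broken down here. In this assay compound 3 gives 90.9%, the highest of the three numbers, and its steps to compound 2 and to compound 1 are both beyond the scatter.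

Compound 4, `N#Cc1c(Nc2ccc(Cl)cc2)nc(SCC(=O)Nn2c(COc3ccc(Cl)cc3Cl)nc3ccccc3c2=O)nc1-c1ccc(O)cc1`, is not yet measured. It differs from compound 3 by chloro in place of hydrogen on an aromatic carbon, which is the same change as from compound 1 to compound 2, made on the other core. The earlier step was modest and upward; the read-out of compound 3 already lies near the top of what an inhibition percentage can show, so a smaller rise is expected from compound 3 to compound 4, about a number 3.1 percentage points higher from compound 3 to compound 4 (within the scatter). Compound 4 is estimated at 94%, between 85% and 99%.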

Compound 4, a percentage reported as inhibition, in the whole organism at one dose (the size of the read-out at that dose, not a potency): 72.7%
Beside the measured number, compound 4's estimate is 21.3 percentage points above it, and the stated range ends above it.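

In this assay, chloro in place of hydrogen on an aromatic carbon gives a number 18.2 percentage points lower from compound 3 to compound 4 (beyond the scatter), and set against the earlier step, the change does not keep its direction from one core to the other: the same change on two cores in this assay, a number 21.8 percentage points higher (beyond the scatter) from compound 1 to compound 2 and a number 18.2 percentage points lower (beyond the scatter) from compound 3 to compound 4, 40 percentage points apart, beyond the scatter of two such steps. The rise seen with the chloro on the core of compound 1 therefore did not carry over to the core of compound 3, although this rests on a single pair for each core. It does not show what lies behind the reversal: the chloro enters a phenyl group in compound 2 and an anilino group in compound 4, and these two pairs cannot separate the effect of the core from that of the ring carrying the chloro.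

Still open, from the compounds shown here alone, is whether a fluoro, a methoxy or an amino group in the chloro's place would follow the same reversal on the two cores. Also open, going by these compounds, is how chloro would behave on the anilino group of a compound with the other substituents of compound 1.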